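Ethoxy for iodo on the aryl of compound 1

The source may report more compounds than this note shows. Statements on the series, on what has been measured and on what is new or still open speak of the compounds shown alone.

The shared core carries a trimethoxyphenyl ketone and a free amine; the variable point is the aryl on the thiophene sulfur side. Compound 1 `COc1cc(C(=O)c2sc(-c3ccc(I)cc3)cc2N)cc(OC)c1OC` is the weakest of the three measured: in a functional assay on MOLT-4 cells (Homo sapiens) for antiproliferative activity (a higher number here means a weaker inhibitor, a lower number a stronger inhibitor), compound 1 gives 190 nM, the highest number of the set. Compound 2 `COc1cc(C(=O)c2sc(-c3ccsc3)cc2N)cc(OC)c1OC` gives 8.8 nM and compound 3 `COc1cc(C(=O)c2sc(-c3cccs3)cc2N)cc(OC)c1OC` gives 8.9 nM; the two thiophenes sit within the scatter of each other, a 1.0-fold higher number from compound 2 to compound 3 (0.00 log units; within the scatter). Against compound 1 both steps are large: a 22-fold lower number from compound 1 to compound 2 (1.33 log units; beyond the scatter) and a 21-fold lower number from compound 1 to compound 3 (1.33 log units; beyond the scatter).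

Compound 4 `CCOc1ccc(-c2cc(N)c(C(=O)c3cc(OC)c(OC)c(OC)c3)s2)cc1` keeps the six-membered ring and changes only its substituent: ethoxy in place of iodo on an aromatic carbon. Within the data shown here, no measured step swaps one substituent for another on this ring; the two large steps exchange the whole 4-iodophenyl for a thiophene, so they show that this position is sensitive but not how an ethoxy group behaves there. A change of either direction within a moderate span is therefore plausible, with a modest improvement regarded as the more likely outcome. Compound 4 is estimated at 60 nM, with a range of 10 nM to 400 nM, which means an expected step of a 3.2-fold lower number from compound 1 to compound 4 (0.50 log units; beyond the scatter).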

Compound 4, half-maximal inhibitory concentration: 240 nM
Compound 4: the middle estimate sits 4.0-fold (0.60 log units) below what was measured; measured number inside the range.
By their numbers in this assay, from the lowest: compounds 2 and 3 (each within the scatter of the next); then compounds 1 and 4 (each within the scatter of the next).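

In this assay, ethoxy in place of iodo gives a 1.3-fold higher number from compound 1 to compound 4 (0.10 log units; within the scatter), the first substituent exchange read on this six-membered ring, and it lies within the scatter even though the two groups differ in size and only ethoxy carries a hydrogen-bond acceptor. The steps from the thiophenes remain large, a 27-fold higher number from compound 3 to compound 4 (1.43 log units; beyond the scatter) and a 27-fold higher number from compound 2 to compound 4 (1.44 log units; beyond the scatter), so among the four compounds shown, the 4-iodophenyl and 4-ethoxyphenyl compounds group together, well apart from the two thiophenes, and none goes against this grouping. Nothing available here speaks to why the two substituents read alike or why the thiophenes stand apart.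

The compounds shown leave open whether the distance from the thiophenes belongs to the six-membered ring itself or to having any substituent on it, a question that an unsubstituted phenyl would address. They also leave open whether the flat reading between iodo and ethoxy would hold for a fluoro, an amine or a carboxylic acid at the same place.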